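Pyrazole Substitution on a Kinase Inhibitor Core

The compounds below may be only part of what the source reports. "The series", "measured", "known", "first", "only" and "open" are said of these compounds alone.

Measured compounds:
Compound 1, `C[C@@H]1CCCN1c1c(C#N)c2c(N)nc(Nc3cn[nH]c3)nc2n1C`; in an assay on isolated protein for inhibition of Leucine-rich repeat serine/threonine-protein kinase 2 variant G2019S (Homo sapiens), read by TR-FRET and LanthaScreen, with stated times of 50 min and 30 min, in the presence of a further agent that is not named here (a higher number here means a weaker inhibitor, a lower number a stronger inhibitor), compound 1 gives 6 nM.
Compound 2, `C[C@@H]1CCCN1c1c(C#N)c2c(N)nc(Nc3cn(C)nc3Cl)nc2n1C`; in this assay compound 2 gives 21 nM.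

Compound 2 holds the highest number of the two; its nearest neighbour is compound 1, and the step of a 3.5-fold higher number from compound 1 to compound 2 (0.54 log units; beyond the scatter) lies beyond the scatter. Compound 3, `Cc1n[nH]cc1Nc1nc(N)c2c(C#N)c(N3CCC[C@H]3C)n(C)c2n1`, differs from compound 2 by 3-methyl-1H-pyrazol-4-yl in place of 3-chloro-1-methyl-1H-pyrazol-4-yl on a nitrogen on an aromatic ring. This change removes the chlorine and the methyl on the ring nitrogen that came in with compound 2, restoring the hydrogen-bond donor of compound 1 while keeping a methyl on the pyrazole. Within the data shown here, it therefore partly reverses the only measured step, a 3.5-fold higher number from compound 1 to compound 2 (0.54 log units; beyond the scatter); no measured step isolates the methyl alone. The step expected for compound 3 is a 2.3-fold lower number from compound 2 to compound 3 (0.37 log units; beyond the scatter), which would place it nearer compound 1 than compound 2. Compound 3 is thus estimated at 9 nM, within 4 nM to 25 nM.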

Compound 3, half-maximal inhibitory concentration: 27 nM
Compound 3: middle estimate off by 3.0-fold (0.48 log units), on the low side, and the stated range ends below it.
By their numbers in this assay, from the lowest: compound 1; then compounds 2 and 3 (each within the scatter of the next).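

In this assay, methyl in place of hydrogen on an aromatic carbon of the pyrazole gives, taken alone, a 4.5-fold higher number from compound 1 to compound 3 (0.65 log units; beyond the scatter), so this single change, with the hydrogen on the ring nitrogen still present, is enough to separate the compounds. Putting 3-methyl-1H-pyrazol-4-yl in place of 3-chloro-1-methyl-1H-pyrazol-4-yl brings back a hydrogen-bond donor, yet compound 2 and compound 3 cannot be told apart, at a 1.3-fold higher number from compound 2 to compound 3 (0.11 log units; within the scatter). Among these compounds, both substituted pyrazoles therefore stand beyond the scatter from the unsubstituted 1H-pyrazol-4-yl of compound 1.

From the compounds shown here alone, the separate contributions of the chlorine and of the methyl on the ring nitrogen remain open. So does whether fluorine, methoxy or an amine on that aromatic carbon would match methyl. Nothing available here explains these steps.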